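The source may report more compounds than this note shows. Statements on the series, on what has been measured and on what is new or still open speak of the compounds shown alone.

Two compounds of this series have been run in an assay on HEK293 cells for activation of cGMP-dependent protein kinase 1 (Homo sapiens), read by HTRF, with a stated time of 3 h; on this read-out lower numbers stand for an effect already at smaller amounts and higher numbers for an effect only at larger amounts of compound. Compound 1 `O=C(O)c1cncc(CN2CCC[C@H](O[C@H](CO)c3cc(Cl)cc(Cl)c3)[C@@H]2c2ccccc2)c1` gives 28000 nM and stands at the high end of the two numbers available. Compound 2 `COC(=O)Nn1c(C[C@H]2CCC[C@H](OCc3cc(C(F)(F)F)cc(C(F)(F)F)c3)[C@@H]2c2ccccc2)n[nH]c1=O` gives 12000 nM in this assay, and the gap between the two lies beyond the usual scatter, so compound 1 is the weaker of the pair as measured.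

Compound 3 `O=C(O)c1ccc(CN2CCC[C@H](O[C@H](CO)c3cc(Cl)cc(Cl)c3)[C@@H]2c2ccccc2)cc1` has not yet been measured in this assay. It differs from compound 1 in a single place: 4-carboxyphenyl in place of 5-carboxypyridin-3-yl on a saturated chain carbon bound to an amine nitrogen in a ring. The aromatic ring that carries the carboxylic acid loses its ring nitrogen and becomes a carbon-only ring, while the acid, its attachment through the saturated chain carbon to the ring amine nitrogen, and the remainder of the shared core are kept unchanged. Among the compounds with values here, no pair of measured compounds shows this change, so its size cannot be read from the data at hand.

The expectation is that a 1.3-fold lower number from compound 1 to compound 3 (0.10 log units; within the scatter) stays small, without a clear direction beyond the scatter. Compound 3 is accordingly expected to give about 22000 nM in this assay, within a range of 8000 nM to 60000 nM.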

Compound 3, half-maximal effective concentration: 15000 nM
Compound 3: the middle estimate sits 1.5-fold (0.17 log units) above what was measured; low and high end bracket the measured number.
By their numbers in this assay, from the lowest: compounds 2, 3 and 1 (each within the scatter of the next, the first and the last beyond it).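

In this assay, within the data shown here, putting 4-carboxyphenyl in place of 5-carboxypyridin-3-yl on a saturated chain carbon bound to an amine nitrogen in a ring gives a 1.9-fold lower number from compound 1 to compound 3 (0.27 log units; within the scatter), the first reading of a single change at this place, and it shows that this exchange of one acid-bearing aromatic ring for the other leaves the result within the scatter. Among these compounds, the two group names show that the step combines loss of the ring nitrogen with a different placing of the carboxy group, so the single step does not separate these two differences, and either could contribute to the result. No measurement at hand offers an explanation for this step.

The compounds shown leave open how the read-out responds when the carboxylic acid of compound 3 is replaced, for example by a carboxamide or a tetrazole. Also open, as far as these compounds go, is whether a longer chain between the aromatic ring and the ring amine nitrogen would move the number beyond the scatter from compound 3.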